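Aryl amide series: nitrile on the pyridine ring

A few compounds are considered here, and "the series" means these few. Any claim that something is new, unique, unknown or untested is made for them only; others in the source may bear on it.

Measured so far:
compound 1 `Cc1cccnc1-c1ccc(C(=O)Nc2ccc(C(C)C)cc2)cc1`: 43 nM
compound 2 `Cc1cccnc1-c1ccc(C(=O)Nc2ccc(C(C)(C)C)cc2)cc1`: 9 nM
compound 3 `CC(C)(C)c1ccc(NC(=O)c2ccc(-c3ccccn3)cc2)cc1`: 8 nM

In a functional assay for antagonist activity at transient receptor potential cation channel subfamily V member 1 (Rattus norvegicus) (on this read-out higher numbers stand for weaker inhibition and lower numbers for stronger inhibition), compound 3 gives the lowest of the three numbers; compound 2 sits within the scatter of it, and compound 1 is the furthest off. The step of a 4.8-fold lower number from compound 1 to compound 2 (0.68 log units; beyond the scatter) is the only one of modest size, while the step of a 1.1-fold lower number from compound 2 to compound 3 (0.05 log units; within the scatter) stays within the scatter.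

Compound 4 `CC(C)(C)c1ccc(NC(=O)c2ccc(-c3ncccc3C#N)cc2)cc1` is not yet measured. It differs from compound 3 by cyano in place of hydrogen on an aromatic carbon, a change on the pyridine ring of the shared core. The step of a 1.1-fold lower number from compound 2 to compound 3 (0.05 log units; within the scatter) bears most directly on it, as it also exchanges a substituent for hydrogen on an aromatic carbon of that ring, and it lay within the scatter. The step of a 4.8-fold lower number from compound 1 to compound 2 (0.68 log units; beyond the scatter) concerns a different part of the molecule and does not bear on the change here. Within the data shown here, no measured pair shows a nitrile entering on an aromatic carbon, so the expectation rests on the quiet behaviour of that ring position alone. Compound 4 is therefore expected to sit close to compound 3, with a step of about a 1.3-fold higher number from compound 3 to compound 4 (0.10 log units; within the scatter) in this assay, not beyond the scatter. The estimate for compound 4 in this assay is 10 nM, within a range from 4 nM to 30 nM.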

Compound 4, half-maximal inhibitory concentration: 13 nM
Estimate against measurement, compound 4: 1.3-fold (0.11 log units) below, within the range that was stated.
By their numbers in this assay, from the lowest: compounds 3, 2 and 4 (each within the scatter of the next); then compound 1.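

In this assay the aromatic carbon ortho to a large group and two atoms from the ring nitrogen now carries hydrogen, methyl or cyano across compound 2, compound 3 and compound 4, and neither a 1.6-fold higher number from compound 3 to compound 4 (0.21 log units; within the scatter) nor a 1.4-fold higher number from compound 2 to compound 4 (0.16 log units; within the scatter) leaves the scatter. The earlier compounds shown here showed only methyl against hydrogen here; the 3-cyanopyridin-2-yl group extends this to a substituent with a triple bond and a hydrogen-bond acceptor, and the read-out still does not separate the three. Nothing at hand accounts for this flat response.

Going by these compounds, whether it persists with an amine, a carboxylic acid or a longer chain at this carbon stays open. Also open, on these data alone, is whether cyano behaves the same way with the isopropyl group of compound 1 on the other side of the amide.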